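Bromophenyl swap on the carbonyl: compound 3 to compound 4

A few compounds are considered here, and "the series" means these few. Any claim that something is new, unique, unknown or untested is made for them only; others in the source may bear on it.

Measured in a functional assay on MCF7 cells (Homo sapiens) for inhibition, read by MTT assay, with a stated time of 24 h; a higher number here means a weaker inhibitor of growth, a lower number a stronger inhibitor of growth:
- compound 1 `COc1ccc2c(c1)c(-c1nc3ccccc3n1C(=O)c1cccc(Br)c1)cn2C` gives 52700 nM
- compound 2 `Cn1cc(-c2nc3ccccc3n2C(=O)c2ccccc2)c2cc(Br)ccc21` gives 50300 nM
- compound 3 `Cn1cc(-c2nc3ccccc3n2C(=O)c2ccccc2Br)c2cc(Br)ccc21` gives 73600 nM

All three numbers sit close together. The number for compound 3 lies within the scatter of those for compound 1 and compound 2, so no order can be read among them.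

Compound 4 `Cn1cc(-c2nc3ccccc3n2C(=O)c2cccc(Br)c2)c2cc(Br)ccc21` is related to compound 3 by one change, (3-bromophenyl in place of 2-bromophenyl on a carbonyl carbon), which places 3-bromophenyl in place of 2-bromophenyl on a carbonyl carbon. Among the measured compounds shown here, the one measured step that bears on this is a 1.5-fold higher number from compound 2 to compound 3 (0.17 log units; within the scatter), bromo in place of hydrogen on an aromatic carbon, and it stays within the scatter. Compound 1 already carries 3-bromophenyl on its carbonyl and gives 52700 nM, although its core differs from that of compound 4. No step beyond the scatter is therefore expected in this assay. The estimated step is a 1.3-fold lower number from compound 3 to compound 4 (0.10 log units; within the scatter). For compound 4 the expected value is 58000 nM, with an estimated range of 32000 nM to 100000 nM.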

Compound 4, concentration for 50% growth inhibition: 68200 nM
The estimate for compound 4 lay 1.2-fold (0.07 log units) below the measured number; the measured number falls inside the stated range.
By their numbers in this assay, from the lowest: compounds 2, 1, 4 and 3 (each within the scatter of the next).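

In this assay, 3-bromophenyl in place of 2-bromophenyl on a carbonyl carbon gives a 1.1-fold lower number from compound 3 to compound 4 (0.03 log units; within the scatter), so this swap of the bromophenyl produces no readable change at this position. The two other single changes leading to compound 4 also stay within the scatter: a 1.4-fold higher number from compound 2 to compound 4 (0.13 log units; within the scatter) with bromo in place of hydrogen, and a 1.3-fold higher number from compound 1 to compound 4 (0.11 log units; within the scatter) with bromo in place of methoxy. No supporting data on hand account for these numbers.

Going by these compounds, all four compounds give numbers within the scatter of their neighbours, so it remains open whether any change on the carbonyl side can shift the read-out at all. An amine or a carboxylic acid on that aromatic ring, or a longer chain in place of the ring, would test this.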